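A few compounds are considered here, and "the series" means these few. Any claim that something is new, unique, unknown or untested is made for them only; others in the source may bear on it.

Two compounds carry a methanesulfonamide core in which one nitrogen substituent is a benzyl group and the other ends in a carboxylic acid. Compound 1 `CC(C)(C)c1ccc(CN(Cc2cccc(CCC(=O)O)c2)S(C)(=O)=O)cc1` pairs a tert-butyl-substituted benzyl group with a shorter acid-bearing arm, and in an assay on HEK293 cells for inhibition of prostaglandin E2 receptor EP2 subtype (Rattus norvegicus) (a lower number here means a stronger inhibitor, a higher number a weaker inhibitor), compound 1 gives 379 nM. Compound 2 `CCCCC(O)c1ccc(CN(CCCCCCC(=O)O)S(C)(=O)=O)cc1` instead bears a 1-hydroxypentyl group on the benzyl ring and a seven-carbon acid chain, and in this assay compound 2 gives 502 nM. The two numbers lie within the scatter of one another, so nothing separates compound 2 from compound 1 on these data.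

Compound 3 `CCCCCC(=O)c1ccc(CN(CCCCCCC(=O)O)S(C)(=O)=O)cc1` keeps the whole of compound 2 except for one change: pentylcarbonyl in place of 1-hydroxypentyl on an aromatic carbon. Within the data shown here, no measured pair shows what this particular change does. Since the rest of the molecule is unchanged and the entering group is close in size to the leaving one, the step from compound 2 to compound 3 is expected to stay within the scatter, a 1.1-fold higher number from compound 2 to compound 3 (0.04 log units; within the scatter). Compound 3 is therefore estimated to give about 550 nM in this assay, most likely between 200 nM and 1500 nM.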

Compound 3, half-maximal inhibitory concentration: 636 nM
Compound 3: middle estimate off by 1.2-fold (0.06 log units), on the low side; the range from low to high includes it.
By their numbers in this assay, from the lowest: compounds 1, 2 and 3 (each within the scatter of the next).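

In this assay, exchanging 1-hydroxypentyl for pentylcarbonyl on the aromatic carbon para to a large group gives a 1.3-fold higher number from compound 2 to compound 3 (0.10 log units; within the scatter), the first step measured at this position. The entering group has one more heavy atom and a double bond outside aromatic rings, and it lacks the hydrogen-bond donor of the leaving group, yet these differences in structure do not separate compound 3 from compound 2 on these data, so this single exchange shows that a hydroxyl-bearing and a carbonyl-bearing five-carbon-tail substituent can occupy this place without a difference that exceeds the scatter. No independent measurement is available to explain this result.

What the compounds shown leave open is whether an amine or a carboxylic acid on this aromatic carbon, or a longer chain in place of pentylcarbonyl, would give a number beyond the scatter of compound 2 and compound 3. A single step also cannot tell whether the same exchange would give a similar result with a different acid-bearing arm, such as the shorter arm of compound 1.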